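The source may hold more compounds than are shown below. What is called first, only, known or untested is meant among the compounds shown, and "the series" means these compounds.

Measured in a functional assay on U-87MG ATCC cells for antiproliferative activity against U-87 MG (Homo sapiens), read by MTT assay, with a stated time of 48 h; a higher number here means a weaker inhibitor, a lower number a stronger inhibitor:
compound 1 `COc1ccc(-c2nc(SCC(=O)c3sc(-c4ccccc4)nc3C)[nH]c(=O)c2C#N)cc1`: 48400 nM
compound 2 `Cc1nc(-c2ccccc2)sc1C(=O)CSc1nc(-c2ccccc2)c(C#N)c(=O)[nH]1`: 56600 nM

Compound 2 stands level with compound 1 on these two numbers. Among the measured compounds shown here, the only measured step is a 1.2-fold higher number from compound 1 to compound 2 (0.07 log units; within the scatter), so the pair shows no separation.

Compound 3 (`Cc1nc(-c2ccccc2)sc1C(=O)CSc1nc(-c2ccc(Cl)cc2)c(C#N)c(=O)[nH]1`) keeps the core of compound 2 and differs from it as follows: chloro in place of hydrogen on an aromatic carbon. In words, this is chloro in place of hydrogen on an aromatic carbon, phenyl to 4-chlorophenyl.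

For the measured compounds named here, the one measured step bears on this only loosely. a 1.2-fold higher number from compound 1 to compound 2 (0.07 log units; within the scatter) also alters a substituent on an aromatic carbon of that phenyl, but it exchanges methoxy for hydrogen and stays within the scatter. Going by the values given here, no chloro compound has been measured, so the data give no direct reading on this group.

On that basis, no shift beyond the scatter is expected in this assay, and neither direction is favoured. The expected step is a 1.1-fold lower number from compound 2 to compound 3 (0.05 log units; within the scatter). For compound 3 the estimated value is 50000 nM, with an expected range from 22000 nM to 100000 nM.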

Compound 3, half-maximal inhibitory concentration: 43400 nM
For compound 3 the middle estimate is 1.2-fold (0.06 log units) above the measured one; low and high end bracket the measured number.
By their numbers in this assay, from the lowest: compounds 3, 1 and 2 (each within the scatter of the next).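

In this assay, among the compounds shown here, chloro at this place, on an aromatic carbon para to a large group, gives a first reading for a halogen, and the result is no separation from hydrogen: a 1.3-fold lower number from compound 2 to compound 3 (0.12 log units; within the scatter). Chloro also stays level with methoxy at the same place, with a 1.1-fold lower number from compound 1 to compound 3 (0.05 log units; within the scatter), so hydrogen, methoxy and chloro now form a set of three groups on this carbon with all their differences inside the scatter, which the single earlier step could not show. Nothing available explains why these three groups read alike here.

From the compounds shown here alone, whether this flat reading holds for other kinds of group at the same carbon stays open, for example an amine, a carboxylic acid or a longer chain such as butoxy, any of which could separate from compound 3 or leave the series level. The three compounds also share the nitrile, the sulfur-containing link and the methyl, so they say nothing about how much each of those parts contributes to the activity.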